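Pyridine-linked hydroxyphenyl series: cytotoxicity notes

The source may report more compounds than this note shows. Statements on the series, on what has been measured and on what is new or still open speak of the compounds shown alone.

Measured so far:
compound 1 `Oc1ccc(-c2cc(-c3ccsc3)cc(-c3cccc(O)c3)n2)cc1` 2580 nM
compound 2 `Oc1ccc(-c2cc(-c3ccsc3)cc(-c3ccc(O)cc3)n2)cc1` 4370 nM
compound 3 `Oc1cccc(-c2cc(-c3ccco3)cc(-c3cccc(O)c3)n2)c1` 5990 nM

The values above come from a functional assay on HeLa cells (Homo sapiens) for cytotoxicity, read by CCK-8 assay; a lower number here means a stronger inhibitor, a higher number a weaker inhibitor. Compound 1 and compound 2 share a core and differ by 4-hydroxyphenyl in place of 3-hydroxyphenyl on an aromatic carbon. The step is a 1.7-fold higher number from compound 1 to compound 2 (0.23 log units; within the scatter), so the two compounds cannot be ranked against each other on this assay. Compound 3 carries a different core; the difference between the core of compound 3 and the core of compound 1 is not broken down here. Compound 3 gives the highest of the three numbers, within the scatter of compound 2 and beyond the scatter of compound 1.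

Compound 4 `Oc1ccc(-c2cc(-c3ccco3)cc(-c3cccc(O)c3)n2)cc1` is not yet measured. It differs from compound 3 by 4-hydroxyphenyl in place of 3-hydroxyphenyl on an aromatic carbon. Within the data shown here, this is the same kind of change as the one from compound 1 to compound 2, though the surroundings differ: in compound 1 the place is meta to a 4-hydroxyphenyl group and meta to a thiophen-3-yl group, in compound 3 it is meta to a 3-hydroxyphenyl group and meta to a furan-2-yl group. Among the measured compounds shown here, the only comparable step available is a 1.7-fold higher number from compound 1 to compound 2 (0.23 log units; within the scatter), which lies within the scatter. For the measured compounds named here, on that basis a step of similar size, a 1.5-fold higher number from compound 3 to compound 4 (0.18 log units; within the scatter), is expected from compound 3 to compound 4 in this assay, with the wide range reflecting that only one prior instance of the change exists. Compound 4 is therefore estimated at 9000 nM, between 4500 nM and 18000 nM.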

Compound 4, half-maximal inhibitory concentration: 5170 nM
Compound 4: the middle estimate sits 1.7-fold (0.24 log units) above what was measured, within the range that was stated.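

In this assay, 4-hydroxyphenyl in place of 3-hydroxyphenyl on the core of compound 3 gives a 1.2-fold lower number from compound 3 to compound 4 (0.06 log units; within the scatter), and the two instances of this change can be set side by side: the same change on two cores in this assay, a 1.7-fold higher number (0.23 log units; within the scatter) from compound 1 to compound 2 and a 1.2-fold lower number (0.06 log units; within the scatter) from compound 3 to compound 4, 2.0-fold (0.29 log units) apart, within the scatter of two such steps. The change therefore carries between these two cores without a readable difference, and on neither core does it move the number beyond the scatter. This does not show that the change is without effect in general or that it would behave alike on other cores, as two pairs inside the scatter fix neither a direction nor a size; furan-2-yl in place of thiophen-3-yl, with a 2.0-fold higher number from compound 1 to compound 4 (0.30 log units; within the scatter), likewise leaves compound 1 and compound 4 unranked.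

Open is whether the hydroxyl groups matter at all, as every compound shown carries hydroxyphenyl groups and none has a methoxy group, an amine or a carboxylic acid on those rings. Also open, as far as these compounds go, is how the series responds to a group of a different kind in place of furan-2-yl or thiophen-3-yl, such as a plain phenyl ring or a longer alkyl chain.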